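Chloro for fluoro on the lowest compound

The compounds below may be only part of what the source reports. "The series", "measured", "known", "first", "only" and "open" are said of these compounds alone.

In an ADME assay on the whole organism for metabolic stability, with Rattus norvegicus as the target (a higher number here means that the compound lasts longer, a lower number that the compound disappears faster), compound 3 `O=S(=O)(c1cc(F)c(O)c2ncccc12)N1CCCC1` gives 2.8 h, the lowest of the three numbers at hand and beyond the scatter from the other two. Compound 4 `O=S(=O)(c1cc(Cl)c(O)c2ncccc12)N1CCCC1` differs from it in one place: chloro in place of fluoro on an aromatic carbon. This is chloro in place of fluoro on an aromatic carbon, ortho to a hydroxy group.

Within the data shown here, no measured step isolates this swap. Among the measured compounds shown here, the only measured step, a 1.2-fold higher number from compound 1 to compound 2 (0.09 log units; within the scatter), is cyclopentyl in place of 4-fluorophenyl on a sulfonyl sulfur, so it shows a change at the sulfonyl group rather than at the halogen. Compound 1 `O=S(=O)(c1ccc(F)cc1)c1cc(Cl)c(O)c2ncccc12` gives 8.9 h and compound 2 `O=S(=O)(c1cc(Cl)c(O)c2ncccc12)C1CCCC1` gives 11 h. Both carry chloro, but both also differ from compound 3 at the sulfonyl group, so they offer only indirect support.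

On the strength of those two values, a moderate rise is expected, a 2.1-fold higher number from compound 3 to compound 4 (0.33 log units; beyond the scatter). Compound 4 is estimated at 6 h, with an expected range of 3 h to 12 h.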

Compound 4, half-life: 8.6 h
Compound 4: middle estimate off by 1.4-fold (0.16 log units), on the low side, within the range that was stated.
By their numbers in this assay, from the lowest: compound 3; then compounds 4, 1 and 2 (each within the scatter of the next).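

Among these compounds, compound 4 gives the first direct reading of chloro in place of fluoro at this position, ortho to a hydroxy group, in this assay (a 3.1-fold higher number from compound 3 to compound 4 (0.49 log units; beyond the scatter)), and this step lies beyond the scatter. Among the three chloro compounds, the group on the sulfonyl sulfur makes no readable difference, since pyrrolidin-1-yl in place of cyclopentyl (a 1.3-fold lower number from compound 2 to compound 4 (0.11 log units; within the scatter)) and pyrrolidin-1-yl in place of 4-fluorophenyl (a 1.0-fold lower number from compound 1 to compound 4 (0.01 log units; within the scatter)) both stay within the scatter. Nothing at hand bears on what lies behind the halogen step.

The compounds shown leave open whether the halogen step would hold with cyclopentyl or 4-fluorophenyl on the sulfonyl sulfur. They also leave open what bromo or methyl would give at this position, or what methoxy would give in place of the hydroxy group.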